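The source may report more compounds than this note shows. Statements on the series, on what has been measured and on what is new or still open speak of the compounds shown alone.

Compound 1 `COC(=O)C1=C(C)N=C(C)/C(=C(\O)OC)C1c1cc(Cl)cc(Cl)c1`: 93.3 nM
Compound 2 `COC(=O)C1=C(C)N=C(C)/C(=C(\O)OC)C1c1ccccc1C#N`: 15.9 nM
Compound 3 `COC(=O)C1=C(C)N=C(C)/C(=C(\O)OC)C1c1cccc(C)c1`: 110 nM

All three values come from a functional assay (muscle tissue) with Cavia porcellus as the target; on this read-out higher numbers stand for an effect only at larger amounts of compound and lower numbers for an effect already at smaller amounts. Compound 3 stands level with compound 1, as the step of a 1.2-fold higher number from compound 1 to compound 3 (0.07 log units; within the scatter) shows. Compound 2 lies clearly lower than both, with a 5.9-fold lower number from compound 1 to compound 2 (0.77 log units; beyond the scatter) and a 6.9-fold higher number from compound 2 to compound 3 (0.84 log units; beyond the scatter).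

The next molecule, compound 4 `COC(=O)C1=C(C)N=C(C)/C(=C(\O)OC)C1c1cc(C)ccc1C`, differs from compound 3 in one place: methyl in place of hydrogen on an aromatic carbon. The new methyl replaces hydrogen on an aromatic carbon, ortho to a large group and para to a methyl group.

For the measured compounds named here, no measured step adds a methyl, so the evidence is indirect. The closest guide is compound 2, whose 2-cyanophenyl also fills the position taken by the new methyl in the 2,5-dimethylphenyl, and which shows a 6.9-fold higher number from compound 2 to compound 3 (0.84 log units; beyond the scatter). A nitrile is not a methyl, however, so only part of that step is expected to carry over, and a result within the scatter remains possible in this assay.

The expected change is modest and towards a lower number, a 2.2-fold lower number from compound 3 to compound 4 (0.34 log units; beyond the scatter). The estimated value for compound 4 is 50 nM, with an expected range of 14 nM to 180 nM.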

Compound 4, half-maximal effective concentration: 100 nM
Compound 4: middle estimate off by 2.0-fold (0.30 log units), on the low side, and the stated range covers the measured number.
By their numbers in this assay, from the lowest: compound 2; then compounds 1, 4 and 3 (each within the scatter of the next).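

In this assay the step of a 1.1-fold lower number from compound 3 to compound 4 (0.04 log units; within the scatter) shows that methyl in place of hydrogen on this aromatic carbon, ortho to a large group, leaves the number unchanged within the scatter. Occupying this place is therefore not enough to match compound 2, as a 6.3-fold higher number from compound 2 to compound 4 (0.80 log units; beyond the scatter) stands beyond the scatter, while a 1.1-fold higher number from compound 1 to compound 4 (0.03 log units; within the scatter) puts the 2,5-dimethylphenyl level with the 3,5-dichlorophenyl. No measurement at hand gives a reason for the separate standing of compound 2.

On these data alone, whether the lower number of compound 2 belongs specifically to its nitrile remains open. An amine or a carboxylic acid on the same aromatic carbon could test whether other groups there move the number as the nitrile does, or leave it as the methyl does.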